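Notes on compound 4: trifluoromethyl removed from compound 3

The source may report more compounds than this note shows. Statements on the series, on what has been measured and on what is new or still open speak of the compounds shown alone.

- compound 1 `O=C(NCc1ccc(S(=O)(=O)c2ccccc2)cc1)c1nc2cnccc2[nH]1`: 7.3%
- compound 2 `O=C(NCc1ccc(S(=O)(=O)c2ccccc2C(F)(F)F)cc1)c1cc2cnccc2[nH]1`: 41%
- compound 3 `O=C(NCc1ccc(S(=O)(=O)c2cccc(C(F)(F)F)c2)cc1)c1cc2cnccc2[nH]1`: 49%

In an ADME assay on microsomes from liver (Mus musculus) for metabolic stability, read by LC-MS, with a stated time of 30 min, tested at 1 uM (on this read-out higher numbers stand for a more stable compound and lower numbers for a less stable compound), compound 3 gives 49%. Together with compound 2 it sits within the scatter at the top of the three numbers, and compound 1 lies beyond the scatter beneath it.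

The next compound is compound 4 `O=C(NCc1ccc(S(=O)(=O)c2ccccc2)cc1)c1cc2cnccc2[nH]1`, described by hydrogen in place of trifluoromethyl on an aromatic carbon, meta to a large group. Among the compounds with values here, the one measured step bearing on this group, a number 8 percentage points higher from compound 2 to compound 3 (within the scatter), only exchanges one trifluoromethylphenyl for another and stays within the scatter. Within the data shown here, no measured pair shows the removal of the group itself. Compound 1 also lacks trifluoromethyl and gives 7.3%, but the core of compound 1 differs from that of compound 3, so it is only a weak guide. A fall is therefore expected, with wide uncertainty.

The expected change is a number 22 percentage points lower from compound 3 to compound 4 (beyond the scatter). The estimate for compound 4 is 27%, with an expected range of 10% to 48%.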

Compound 4, percent of the compound remaining: 54%
For compound 4 the middle estimate is 27 percentage points below the measured one, and the stated range ends below it.
By their numbers in this assay, from the lowest: compound 1; then compounds 2, 3 and 4 (each within the scatter of the next, the first and the last beyond it).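

In this assay the trifluoromethyl group proves dispensable at this position, with a number 5 percentage points higher from compound 3 to compound 4 (within the scatter) when 3-(trifluoromethyl)phenyl gives way to phenyl. The comparison with the other trifluoromethyl isomer reads differently, with a number 13 percentage points higher from compound 2 to compound 4 (beyond the scatter) as a modest step when hydrogen replaces trifluoromethyl. With the phenyl sulfone the same on both sides, the core exchange alone gives a number 46.7 percentage points higher from compound 1 to compound 4 (beyond the scatter).

As far as these compounds go, whether methyl, chlorine, methoxy or an amine at this place would hold the number, and whether trifluoromethyl would change anything on the core of compound 1, stays open. Nothing measured here gives a reason for any of these steps.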